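A few compounds are considered here, and "the series" means these few. Any claim that something is new, unique, unknown or untested is made for them only; others in the source may bear on it.

Compound 1 `O=C(CSc1nc(Nc2ccccc2)c2ccccc2n1)Nc1cccc(Cl)c1` and compound 2 `O=C(CSc1nc(Nc2ccccc2)c2ccccc2n1)Nc1cccc(Br)c1` share a core and differ only in one halogen. In a functional assay on MDA-MB-231 cells (Homo sapiens) for inhibition, read by MTT assay, with a stated time of 72 h (a lower number here means a stronger inhibitor, a higher number a weaker inhibitor), compound 1 gives 16500 nM, and compound 2 gives 17500 nM. The change between them is bromo in place of chloro on an aromatic carbon and it produced a 1.1-fold higher number from compound 1 to compound 2 (0.03 log units; within the scatter), so the two values cannot be told apart in this assay.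

Compound 3 `C=CC(=O)Nc1cccc(NC(=O)CSc2nc(Nc3ccc(Cl)cc3)c3ccccc3n2)c1` is built on a different core; the difference between the two cores is not broken down here. In this assay compound 3 gives 10300 nM, a value within the scatter of those of compound 1 and compound 2.

Compound 4 `C=CC(=O)Nc1cccc(NC(=O)CSc2nc(Nc3ccc(Br)cc3)c3ccccc3n2)c1` has not yet been measured. It differs from compound 3 by bromo in place of chloro on an aromatic carbon. This is the same kind of change as that from compound 1 to compound 2, but the place is not identical: there the halogen sits meta to a large group, here para to a large group. Since the earlier exchange gave a 1.1-fold higher number from compound 1 to compound 2 (0.03 log units; within the scatter), a similarly small step, a 1.1-fold higher number from compound 3 to compound 4 (0.05 log units; within the scatter), is expected for compound 4. Compound 4 is therefore estimated to give 11500 nM, with a likely range from 6000 nM to 23000 nM.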

Compound 4, half-maximal inhibitory concentration: 17300 nM
For compound 4 the middle estimate is 1.5-fold (0.18 log units) below the measured one, and the stated range covers the measured number.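

In this assay, putting bromo in place of chloro on the phenyl ring of compound 3 gave a 1.7-fold higher number from compound 3 to compound 4 (0.23 log units; within the scatter), a step too small to separate the two compounds. Set beside the same exchange on the other core, the new step does not differ from the earlier one: the same change on two cores in this assay, a 1.1-fold higher number (0.03 log units; within the scatter) from compound 1 to compound 2 and a 1.7-fold higher number (0.23 log units; within the scatter) from compound 3 to compound 4, 1.6-fold (0.20 log units) apart, within the scatter of two such steps. This shows that in these two pairs the exchange carried across both cores without a step beyond the scatter, but it does not show that the change is without effect in general, and two pairs cannot predict the outcome on a third core.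

The compounds shown leave open what would happen if the halogen were replaced by something other than chloro or bromo, such as fluoro, a methoxy group, an amine or a carboxylic acid. They also leave open whether any group at this place could move the number beyond the scatter, in either direction.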